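The source may report more compounds than this note shows. Statements on the series, on what has been measured and on what is new or still open speak of the compounds shown alone.

Compound 1 `O/N=C(/Nc1ccccc1)c1ccc2occc2c1`: in an assay on isolated protein for inhibition of Indoleamine 2,3-dioxygenase 1 (Homo sapiens), read by spectrophotometry (on this read-out higher numbers stand for weaker inhibition and lower numbers for stronger inhibition), compound 1 gives > 30000 nM, which is a limit of the assay.
Compound 2 `O/N=C(/NCc1cccc(Cl)c1)c1ccc2occc2c1`: in this assay compound 2 gives > 30000 nM, again a limit and not a number.
Compound 3 `O/N=C(/NCc1ccc(F)c(Cl)c1)c1ccc2occc2c1`: in this assay compound 3 gives 22000 nM.

Going by these compounds, compound 2 therefore stands at the limit of > 30000 nM in this assay, at which 2 of the 3 values shown sit, so its true position is unknown apart from that ceiling. The change to compound 4 `O/N=C(/NCC1CC1)c1ccc2occc2c1` is cyclopropyl in place of 3-chlorophenyl on a saturated chain carbon bound to an amine nitrogen. Going by the values given here, only one measured step exists, an at least 1.3-fold lower number from compound 2 to compound 3 (0.13 log units; that floor lies within the scatter), and it concerns a fluoro added to the aromatic ring of the benzyl group, a group that compound 4 no longer carries; it bears on the present change only in that it stays within the scatter. Among the compounds with values here, no measured compound carries a cyclopropyl, so the step has no direct precedent. Within the data shown here, with compound 2 sitting at a limit and no step pointing toward stronger inhibition, the expected step is a number no higher from compound 2 to compound 4 (the limit leaves the size open). Compound 4 is thus estimated at 30000 nM, with a range of 10000 nM to 100000 nM, and most probably reported as a limit.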

Compound 4, half-maximal inhibitory concentration: > 30000 nM
Compound 4 ended at the assay's limit (the forecaster's own chance of this, stated with the estimate: 70%); the middle value sits exactly at the limit.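

Compound 4 gives > 30000 nM in this assay and that is a limit of the assay. Going by these compounds alone, compound 1 and compound 2 also sit at limits, so no step from either to compound 4 can be read. The compounds shown leave open how strongly compound 4 inhibits and whether cyclopropyl in place of 3-chlorophenyl changes inhibition at all.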